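The compounds below may be only part of what the source reports. "The series", "measured", "known", "first", "only" and "open" are said of these compounds alone.

Measured compounds:
Compound 1, `CC(=O)OC/C(=C\c1ccc(Cl)cc1)C(=O)c1ccccc1`, gives 2300 nM.
Compound 2, `CC(=O)OC/C(=C\c1ccc(Cl)cc1)C(=O)c1ccc(Cl)cc1`, gives 4000 nM.
Compound 3, `CC(=O)OC/C(=C\c1ccc(Cl)cc1Cl)C(=O)c1ccc(Cl)cc1`, gives 3200 nM.

All three numbers come from a functional assay on HBL-100 cells (Homo sapiens) for inhibition, read by sulforhodamine B assay, with a stated time of 48 h; a higher number here means a weaker inhibitor of growth, a lower number a stronger inhibitor of growth. Among them, compound 2 holds the highest number, but its neighbours sit close: the step of a 1.7-fold higher number from compound 1 to compound 2 (0.24 log units; within the scatter) and the step of a 1.3-fold lower number from compound 2 to compound 3 (0.10 log units; within the scatter) both stay within the scatter, so the three compounds cannot be told apart on these data.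

The new compound 4, `CC(=O)OC/C(=C/c1ccc(Cl)cc1)C(=O)c1ccc(Cl)cc1`, differs from compound 2 only as follows: the two compounds have the same atoms and bonds and differ only in configuration as drawn: 1 of 1 stereo elements differ; a double bond is drawn E in compound 2 and Z in compound 4. For the measured compounds named here, none of the measured steps bears on this kind of change; both measured steps concern a chloro in place of hydrogen on an aromatic carbon, and both were small. There is therefore no measured basis for expecting a change in this assay, and the expectation for compound 4 simply rests near the number of compound 2, with a wide range to reflect that a change in drawn configuration has not been tested here. The expected step of no change at the digits printed from compound 2 to compound 4 (within the scatter) is estimated as no change beyond the scatter. Compound 4 is thus expected to give 4000 nM, within an estimated range from 1300 nM to 12000 nM.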

Compound 4, concentration for 50% growth inhibition: 16000 nM
Compound 4: the middle estimate sits 4.0-fold (0.60 log units) below what was measured, outside the stated range (above it).
By their numbers in this assay, from the lowest: compounds 1, 3 and 2 (each within the scatter of the next); then compound 4.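

In this assay, the step from E to Z at the double bond gives a 4.0-fold higher number from compound 2 to compound 4 (0.60 log units; beyond the scatter), so the Z form is the weaker inhibitor of growth in this pair. For the compounds shown here, the chloro changes among the earlier compounds all stayed within the scatter, so this is the first change in the set that clearly moves the number, and it shows that the way the double bond is drawn matters more here than those chloro swaps. The shift can be assigned to the double bond alone because nothing else separates the two structures: the fact that compounds 2 and 4 differ only in the configuration as drawn

As far as these compounds go, this is a single pair, so it remains open whether the Z form would raise the number in the same way with the chloro patterns of compound 1 or compound 3. From the compounds shown here alone, it is also open how either form would respond if an amine or a carboxylic acid stood in place of the acetate ester.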